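Swapping methoxy for chloro on an arylpiperazine

This account rests on a few compounds, and the source may have more. Where it says the series, first, only, none or still open, it means among the compounds named here.

In an assay on cell membranes for binding affinity to Adrenergic receptor alpha-1 (Rattus norvegicus), read by radioligand binding (on this read-out lower numbers stand for stronger inhibition and higher numbers for weaker inhibition), compound 2 `COc1ccccc1N1CCN(CCCCCCn2ncc(N3CCN(C(=O)c4ccco4)CC3)c(Cl)c2=O)CC1` gives 4.1 nM, the higher of the two numbers recorded so far; compound 1 `COc1ccccc1N1CCN(CCCCCn2ncc(N3CCN(C(=O)c4ccco4)CC3)c(Cl)c2=O)CC1` gives 1.9 nM, and that gap lies beyond the usual scatter. Compound 3 `O=C(c1ccco1)N1CCN(c2cnn(CCCCCCN3CCN(c4ccccc4Cl)CC3)c(=O)c2Cl)CC1` has not yet been measured. It differs from compound 2 by chloro in place of methoxy on an aromatic carbon. Among the compounds with values here, no measured pair shows this exchange, so its effect is unknown here. The expectation is a step of a 2.4-fold higher number from compound 2 to compound 3 (0.39 log units; beyond the scatter) toward a higher number, somewhat beyond the scatter. Compound 3 is estimated to give 10 nM in this assay, within a range from 3 nM to 40 nM.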

Compound 3, inhibition constant: 5.7 nM
Beside the measured number, compound 3's estimate is 1.8-fold (0.24 log units) above it; low and high end bracket the measured number.
By their numbers in this assay, from the lowest: compound 1; then compounds 2 and 3 (each within the scatter of the next).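

On an aromatic carbon ortho to a large group, chloro in place of methoxy gives a 1.4-fold higher number from compound 2 to compound 3 (0.14 log units; within the scatter) in this assay. At this position, then, the two groups cannot be told apart in this assay, even though the methoxy's oxygen and hydrogen-bond acceptor are gone. Nothing available here offers a reason for this.

Still open, on these data alone, is how other groups at the same place would read, such as fluoro, methyl or an amine. Also open, as far as these compounds go, is whether chloro would read the same way on the chain of compound 1.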